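Urea tail exchange on a pyrazole scaffold in A498 cells

This account rests on a few compounds, and the source may have more. Where it says the series, first, only, none or still open, it means among the compounds named here.

Measured compounds:
compound 1 `O=C(Nc1cccc(-n2cc(-c3ccncc3)c(-c3ccc(Cl)c(O)c3)n2)c1)Nc1cccc(C(F)(F)F)c1` 2240 nM
compound 2 `COc1cc(-c2nn(-c3cccc(NC(=O)Nc4cc(C(F)(F)F)cc(C(F)(F)F)c4)c3)cc2-c2ccncc2)ccc1Cl` 610 nM

In a functional assay on A498 cells (Homo sapiens) for inhibition, read by sulforhodamine B assay, with a stated time of 48 h (on this read-out higher numbers stand for weaker inhibition and lower numbers for stronger inhibition), compound 1 gives 2240 nM, the higher of the two numbers recorded. Compound 2 gives 610 nM in this assay, a gap that lies beyond the scatter. Compound 3 `O=C(Nc1cccc(-n2cc(-c3ccncc3)c(-c3ccc(Cl)c(O)c3)n2)c1)Nc1ccc(Cl)c(Cl)c1` is not yet measured; it differs from compound 1 by 3,4-dichlorophenyl in place of 3-(trifluoromethyl)phenyl on an amide-type nitrogen. Among the measured compounds shown here, no measured pair isolates this change, so the step is expected to be modest, at most a small move toward stronger inhibition, within or only just beyond the scatter, giving a 1.5-fold lower number from compound 1 to compound 3 (0.17 log units; within the scatter). Compound 3 is estimated at 1500 nM, ranging from 500 nM to 5000 nM.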

Compound 3, half-maximal inhibitory concentration: 940 nM
Estimate against measurement, compound 3: 1.6-fold (0.20 log units) above, and the stated range covers the measured number.
By their numbers in this assay, from the lowest: compounds 2 and 3 (each within the scatter of the next); then compound 1.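

On the amide-type nitrogen, with the core of compound 1 held fixed, 3,4-dichlorophenyl in place of 3-(trifluoromethyl)phenyl gives in this assay a 2.4-fold lower number from compound 1 to compound 3 (0.38 log units; beyond the scatter). Among the compounds shown here, this is the first single-place change, and it shows that the aryl group on this nitrogen alone can shift the number beyond the scatter. Nothing available explains why this exchange has that effect.

Still open, as far as these compounds go, is whether a carboxylic acid or an amine on that phenyl ring would be tolerated. It is also unclear whether the same exchange would have a similar effect on the core of compound 2.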